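Methoxy for Fluoro on the Anilino Ring of Compound 1

This account rests on a few compounds, and the source may have more. Where it says the series, first, only, none or still open, it means among the compounds named here.

Compound 1 `O=C(/C=C\Nc1ccc(F)cc1)c1nc(-c2ccc(F)cc2)n2ccccc12`: > 30000 nM
Compound 2 `COc1ccc(-c2nc(C(=O)/C=C\Nc3ccc4[nH]ccc4c3)c3ccccn23)cc1`: 17400 nM

In a functional assay on HCT-116 cells (Homo sapiens) for cytotoxicity, read by MTT assay, with a stated time of 48 h (a higher number here means a weaker inhibitor, a lower number a stronger inhibitor), compound 1 gives only a limit of the assay, > 30000 nM. In this assay compound 2 gives 17400 nM. Compound 3 `COc1ccc(N/C=C\C(=O)c2nc(-c3ccc(F)cc3)n3ccccc23)cc1` differs from compound 1 in one place: methoxy in place of fluoro on an aromatic carbon. Among the measured compounds shown here, no step between measured compounds shares this change, so its size is open. Compound 1 sits at the limit of > 30000 nM in this assay, at which 1 of the 2 values shown sits, and a shift beyond the scatter is not expected from these two values. Compound 3 is estimated at 30000 nM, within 12000 nM to 80000 nM. The expected step from compound 1 to compound 3 is a number no higher from compound 1 to compound 3 (the limit leaves the size open), with a limit the more likely outcome.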

Compound 3, half-maximal inhibitory concentration: > 30000 nM
Compound 3 gave a limit, no number; the forecaster's own chance of this, stated with the estimate: 60%; the middle value lies on the limit itself.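

In this assay compound 1 and compound 3 each give only a limit, and no step can be read between them. From the compounds shown here alone, whether methoxy in place of fluoro on an aromatic carbon shifts the value at all, and in which direction, stays open.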